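A few compounds are considered here, and "the series" means these few. Any claim that something is new, unique, unknown or untested is made for them only; others in the source may bear on it.

In a functional assay on PC-3 cells (Homo sapiens) for cytotoxicity, read by sulforhodamine B assay (a lower number here means a stronger inhibitor of growth, a higher number a weaker inhibitor of growth), compound 1 `COc1cccc(OC)c1OCCNCCOc1ccccc1OCc1ccccc1` gives 76900 nM. Among the compounds with values here, compound 2 `COc1cccc(OC)c1OCCNCCOc1ccccc1OCc1cccc(C)c1` gives 32300 nM in this assay, the lowest of the two numbers so far; its only neighbour is compound 1, and the step between them reads a 2.4-fold lower number from compound 1 to compound 2 (0.38 log units; beyond the scatter). Compound 3 `COc1cccc(OC)c1OCCNCCOc1ccccc1OCc1cccc([N+](=O)[O-])c1` differs from compound 2 by nitro in place of methyl on an aromatic carbon. Within the data shown here, the one measured step, a 2.4-fold lower number from compound 1 to compound 2 (0.38 log units; beyond the scatter), added a methyl where compound 3 now carries a nitro, so it bears on this change only loosely and no step with a nitro exists. The expected step is therefore a 1.1-fold lower number from compound 2 to compound 3 (0.03 log units; within the scatter), within the scatter. Compound 3 is expected to give 30000 nM in this assay, between 10000 nM and 90000 nM.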

Compound 3, concentration for total growth inhibition: 38900 nM
Beside the measured number, compound 3's estimate is 1.3-fold (0.11 log units) below it; measured number inside the range.
By their numbers in this assay, from the lowest: compounds 2, 3 and 1 (each within the scatter of the next, the first and the last beyond it).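

In this assay, replacing the methyl with a nitro gives a 1.2-fold higher number from compound 2 to compound 3 (0.08 log units; within the scatter), so this place on the benzyl ring accepts two groups with quite different atoms without a readable change. Compared with the hydrogen of compound 1, the nitro gives a 2.0-fold lower number from compound 1 to compound 3 (0.30 log units; within the scatter), so this step, unlike the methyl step, does not clear the scatter. Nothing measured here explains why methyl and nitro read alike. Going by these compounds, whether an amine or a carboxylic acid at this place would also read like the methyl and nitro remains open.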